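The source may hold more compounds than are shown below. What is called first, only, known or untested is meant among the compounds shown, and "the series" means these compounds.

Going by the values given here, compound 2 `CCOC(=O)C1=C(C)NC(C)=C(C(=O)OCC)C1c1ccc(OCC(=O)Nc2nc3ccccc3s2)cc1` gives 54.5% in a functional assay on the whole organism (strain Wistar) for inhibition, with Rattus norvegicus as the target, read by paw edema, with stated times of 30 min and 1 h, at a dose of 20 mg/kg (on this read-out higher numbers stand for more inhibition at the one dose given (going by the name of the read-out) and lower numbers for less inhibition), the higher of the two numbers measured so far. Among the compounds with values here, the only other measured compound, compound 1 `CCOC(=O)C1=C(C)NC(C)=C(C(=O)OCC)C1c1ccc(OCC(=O)Nc2c(C)cccc2C)cc1`, gives 26.3% in this assay, and the change between them is a number 28.2 percentage points higher from compound 1 to compound 2 (beyond the scatter). Compound 3 `CCOC(=O)C1=C(C)NC(C)=C(C(=O)OCC)C1c1ccc(OCC(=O)NNC(=O)c2ccc(C)cc2)cc1` differs from compound 2 at the same amide-type nitrogen: ((4-methylphenyl)carbonyl)amino in place of 1,3-benzothiazol-2-yl on an amide-type nitrogen. Within the data shown here, the single measured step also swapped the group on this nitrogen and was modest, but no measured step shows this particular replacement, so a moderate change in either direction, or none beyond the scatter, remains possible. Compound 3 is expected to give about 38%, within 20% to 58%. This expectation amounts to a step of a number 16.5 percentage points lower from compound 2 to compound 3 (beyond the scatter).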

Compound 3, a percentage reported as inhibition, in the whole organism at one dose (the size of the read-out at that dose, not a potency): 35.9%
Compound 3: middle estimate off by 2.1 percentage points, on the high side; the range from low to high includes it.
By their numbers in this assay, from the lowest: compounds 1 and 3 (each within the scatter of the next); then compound 2.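

Replacing 1,3-benzothiazol-2-yl with ((4-methylphenyl)carbonyl)amino on the amide-type nitrogen gives, in this assay, a number 18.6 percentage points lower from compound 2 to compound 3 (beyond the scatter). Against 2,6-dimethylphenyl, the same new group gives a number 9.6 percentage points higher from compound 1 to compound 3 (within the scatter), so among these three groups only 1,3-benzothiazol-2-yl stands apart, with its steps to both others beyond the scatter. No evidence available here explains this difference.

The compounds shown leave open whether both rings of 1,3-benzothiazol-2-yl are needed. A thiazol-2-yl or a pyridin-2-yl group on this nitrogen would address that question.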